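A few compounds are considered here, and "the series" means these few. Any claim that something is new, unique, unknown or untested is made for them only; others in the source may bear on it.

In a functional assay on L1210 cells (Mus musculus) for antiproliferative activity, read by MTT assay (on this read-out higher numbers stand for weaker inhibition and lower numbers for stronger inhibition), compound 1 `O=C(N/N=C/c1ccccc1)c1cn(C2CC2)c2cc(N/N=C/c3ccccc3)c(F)cc2c1=O` gives <= 25000 nM, which is a limit and not a number. Compound 2 `COc1cc(/C=N/NC(=O)c2cn(C3CC3)c3cc(N/N=C/c4cc(OC)c(OC)c(OC)c4)c(F)cc3c2=O)cc(OC)c1OC` gives <= 25000 nM, also a limit. The measurements so far therefore rest on (the limit of <= 25000 nM in this assay, at which 2 of the 2 values shown sit). Compound 3 `O=C(N/N=C/c1ccccc1)c1cn(C2CC2)c2cc(N3CCNCC3)c(F)cc2c1=O` keeps the core of compound 1 but changes one group on an aromatic carbon, ortho to a fluoro group: a group of 6 heavy atoms (4 carbon, 2 nitrogen; one six-membered non-aromatic ring with 2 hetero atoms) in place of a group of 9 heavy atoms (7 carbon, 2 nitrogen; one six-membered aromatic ring of carbon only), on an aromatic carbon. Among the measured compounds shown here, no measured step shows what such a swap does, so the expected change, a step that the limit leaves unreadable from compound 1 to compound 3, is no shift beyond the usual scatter in either direction. For compound 3 the estimated value is 14000 nM, with an expected range from 4000 nM to 40000 nM.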

Compound 3, half-maximal inhibitory concentration: <= 25000 nM
Compound 3 was reported as a limit; the forecaster's own chance of this, stated with the estimate: 35%; the middle value is on the limit's open side.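

Among the compounds shown here, compound 1 and compound 3 are both reported as limits, not exact numbers, so no step between them can be read: the limit of <= 25000 nM in this assay, at which 3 of the 3 values shown sit. The compounds shown leave open how strongly each one actually inhibits and whether the piperazin-1-yl swap changes that at all.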